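Series notes: cytotoxicity, compound 4 pending

The source may report more compounds than this note shows. Statements on the series, on what has been measured and on what is new or still open speak of the compounds shown alone.

Measured compounds:
compound 1 `COc1ccc(/C=C2\CN(C)C/C(=C\c3ccccc3F)C2=O)cc1`: 12300 nM
compound 2 `COc1cc(/C=C2\CN(C)C/C(=C\c3ccccc3F)C2=O)cc(OC)c1`: 1240 nM
compound 3 `COc1cc(/C=C2\CN(C)C/C(=C\c3ccccc3F)C2=O)cc(OC)c1OC`: 670 nM

In a functional assay on HepG2 cells (Homo sapiens) for cytotoxicity, read by MTT assay, with a stated time of 24 h (on this read-out lower numbers stand for stronger inhibition and higher numbers for weaker inhibition), compound 2 gives 1240 nM, the second highest of the three numbers; compound 3 is nearest, with a 1.9-fold lower number from compound 2 to compound 3 (0.27 log units; within the scatter), while compound 1 is furthest at 12300 nM. Among the compounds with values here, the only step measured so far concerns a methoxy in place of hydrogen on an aromatic carbon and is within the scatter.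

Compound 4 `COc1cc(/C=C2\CN(C)C/C(=C\c3ccc(Cl)cc3)C2=O)cc(OC)c1` differs from compound 2 by 4-chlorophenyl in place of 2-fluorophenyl on a double-bonded chain carbon bound to a double-bonded ring carbon. Within the data shown here, no measured step touches this part of the molecule, so there is nothing to anchor a direction; the change is expected to stay within the scatter. Compound 4 is therefore estimated at 1200 nM, range 450 nM to 3200 nM. That estimate means a 1.0-fold lower number from compound 2 to compound 4 (0.01 log units; within the scatter), a step expected not to exceed the scatter.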

Compound 4, half-maximal inhibitory concentration: 5950 nM
Beside the measured number, compound 4's estimate is 5.0-fold (0.70 log units) below it, and the stated range ends below it.
By their numbers in this assay, from the lowest: compounds 3 and 2 (each within the scatter of the next); then compound 4; then compound 1.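

The aryl group on the double-bonded chain carbon bound to a double-bonded ring carbon is not a silent place in this assay: 4-chlorophenyl in place of 2-fluorophenyl gives a 4.8-fold higher number from compound 2 to compound 4 (0.68 log units; beyond the scatter). The earlier step concerned only a methoxy on the other aromatic ring, so this single pair is the only read on this part of the molecule. No available evidence bears on this shift.

Going by these compounds, it remains open whether the change of halogen or the change of its place carries the step, since this pair alters both at once. Also open, on these data alone, is how plain phenyl, or a phenyl bearing an amine, would read at this place.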